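The compounds below may be only part of what the source reports. "The series", "measured", "known", "first", "only" and "open" are said of these compounds alone.

Of the compounds shown here, two built on one shared core have been tested in a functional assay on U-251 cells (Homo sapiens) for inhibition, read by sulforhodamine B assay, with a stated time of 48 h, tested at 10 uM; on this read-out higher numbers stand for a weaker effect at the one concentration tested and lower numbers for a stronger effect. Compound 1 `COc1cc(Cl)cc(-c2nn(-c3cccc(NC(=O)c4cccc(C(F)(F)F)c4)c3)cc2-c2ccncc2)c1` gives 49.2%. Compound 2 `O=C(Nc1cccc(-n2cc(-c3ccncc3)c(-c3cc(O)cc(Cl)c3)n2)c1)c1cc(C(F)(F)F)cc(C(F)(F)F)c1` gives 37.2%, the lower of the two numbers and so the stronger effect, a gap from compound 1 that lies beyond the usual scatter. Compound 3 `COc1cc(Cl)cc(-c2nn(-c3cccc(NC(=O)c4cc(C(F)(F)F)cc(C(F)(F)F)c4)c3)cc2-c2ccncc2)c1` has not yet been measured. It differs from compound 2 in a single place: methyl in place of hydrogen on an oxygen on an aromatic ring. Within the data shown here, no measured pair isolates this change, so its effect cannot be read from the numbers at hand. A step of a number 4.8 percentage points higher from compound 2 to compound 3 (within the scatter) is expected, small and not clearly beyond the scatter. Compound 3 is expected to give 42%, within the range 28% to 58%.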

Compound 3, a percentage reported as activity, at one concentration (the size of the read-out at that concentration, not a potency): 60.7%
The estimate for compound 3 lay 18.7 percentage points below the measured number, and the stated range ends below it.
By their numbers in this assay, from the lowest: compound 2; then compound 1; then compound 3.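

In this assay, the change from hydroxy to methoxy on the aromatic ring can now be read on its own, and it weakens the effect, with a number 23.5 percentage points higher from compound 2 to compound 3 (beyond the scatter). Trifluoromethyl in place of hydrogen on an aromatic carbon also weakens it, with a number 11.5 percentage points higher from compound 1 to compound 3 (beyond the scatter). No measurement at hand explains either step. Still open, as far as these compounds go, is how an amine or an ethoxy group would read in place of the hydroxy. Also open, from the compounds shown here alone, is whether the hydroxy to methoxy step keeps its size when only one trifluoromethyl is present.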